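The source may report more compounds than this note shows. Statements on the series, on what has been measured and on what is new or still open speak of the compounds shown alone.

Of the compounds shown here, three have been measured in a functional assay on RS4-11 cells (Homo sapiens) for inhibition, read by CCK-8 assay, with a stated time of 48 h; a lower number here means a stronger inhibitor, a higher number a weaker inhibitor. Compound 1 `CC(C)c1ccc(Oc2ccc(O)c(O)c2)c(-c2ccsc2S(=O)(=O)NCCNC(=S)Nc2cc(C(F)(F)F)cc(C(F)(F)F)c2)c1` gives 3700 nM, compound 3 `COc1ccc(NC(=O)NCCNS(=O)(=O)c2ccc(-c3ccccc3OCc3cccc(O)c3)s2)cc1` gives 9400 nM, and compound 2 `O=C(NCCNS(=O)(=O)c1ccc(-c2ccccc2O[C@H]2CC[C@@H](O)CC2)s1)Nc1ccc([N+](=O)[O-])cc1` gives 12400 nM. Compound 1 thus stands lowest of the three, its nearest neighbour being compound 3 and its furthest compound 2, both separated from it by more than the usual scatter, so that in this series compound 1 is the strongest inhibitor.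

Compound 4 `COc1ccc(Oc2ccc(C(C)C)cc2-c2ccsc2S(=O)(=O)NCCNC(=S)Nc2cc(C(F)(F)F)cc(C(F)(F)F)c2)cc1OC` has not yet been measured. It differs from compound 1 in one place: 3,4-dimethoxyphenyl in place of 3,4-dihydroxyphenyl on an oxygen on an aromatic ring. For the measured compounds named here, no measured pair shows this same change, so the size of its effect in this assay cannot be read from the data at hand. Without such a pair, only a loose expectation is possible: the step from compound 1 to compound 4 is estimated to be modest, most likely a slight weakening, with a real chance that it falls within the scatter, so that a 1.5-fold higher number from compound 1 to compound 4 (0.17 log units; within the scatter) is expected. On that basis compound 4 is expected to give about 5500 nM, somewhere between 1800 nM and 17000 nM.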

Compound 4, half-maximal inhibitory concentration: 5500 nM
The estimate for compound 4 equals the measured number at the digits printed, within the range that was stated.
By their numbers in this assay, from the lowest: compounds 1, 4, 3 and 2 (each within the scatter of the next, the first and the last beyond it).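

In this assay, for the compounds shown here, compounds 1 and 4 form the first pair in this set that differs in one place, and putting 3,4-dimethoxyphenyl in place of 3,4-dihydroxyphenyl on an oxygen on an aromatic ring gives a 1.5-fold higher number from compound 1 to compound 4 (0.17 log units; within the scatter). The 3,4-dimethoxyphenyl group carries none of the hydrogen-bond donors of 3,4-dihydroxyphenyl, so in this one pair those donors are not required for a number of this size. No measurement at hand explains this outcome.

The compounds shown leave open whether 3,4-diethoxyphenyl, an aminophenyl or a carboxyphenyl group at this place would also stay within the scatter of compound 1. They also leave open whether the same change would behave alike on the core of compound 2 or compound 3.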